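A few compounds are considered here, and "the series" means these few. Any claim that something is new, unique, unknown or untested is made for them only; others in the source may bear on it.

Compound 1, `CNc1ncnc2c1ncn2[C@@H]1C(F)=C(CO)[C@@H](O)[C@H]1O`, and compound 2, `OCC1=C(F)[C@@H](n2cnc3c(NC4CC4)ncnc32)[C@H](O)[C@@H]1O`, share one core and differ by cyclopropyl in place of methyl on a nitrogen on an aromatic ring. In a functional assay on MDA-MB-231 cells (Homo sapiens) for cytotoxicity, read by sulforhodamine B assay, with a stated time of 72 h (on this read-out higher numbers stand for weaker inhibition and lower numbers for stronger inhibition), compound 1 gives 8050 nM. For compound 2 this assay reports only a limit, > 100000 nM, so compound 2 sits at the limit of > 100000 nM in this assay, at which 1 of the 2 values shown sits. That single change gave an at least 12-fold higher number from compound 1 to compound 2 (1.09 log units; beyond the scatter). Among the measured compounds shown here, compound 3, `Nc1nc(NC2CC2)c2ncn([C@@H]3C(F)=C(CO)[C@@H](O)[C@H]3O)c2n1`, differs from compound 2 by amino in place of hydrogen on an aromatic carbon; no measured step covers this kind of change, so the only anchor is the limit of compound 2. Compound 3 is therefore expected to stay weak, with an estimated 60000 nM (range 15000 nM to 200000 nM), an expected at least 1.6-fold lower number from compound 2 to compound 3 (0.22 log units; that floor lies within the scatter).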

Compound 3, half-maximal inhibitory concentration: > 100000 nM
Compound 3: only a limit was reported (the forecaster's own chance of this, stated with the estimate: 55%); middle value at least 1.6-fold (0.22 log units) away from the limit.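

In this assay, compound 2 and compound 3 are both reported only as limits, so the step between them cannot be read. Going by these compounds, whether amino in place of hydrogen on an aromatic carbon changes inhibition at all stays open.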